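This account rests on a few compounds, and the source may have more. Where it says the series, first, only, none or still open, it means among the compounds named here.

The measured compounds in a functional assay on A549 cells (Homo sapiens) for cytotoxicity, read by MTT assay, with a stated time of 72 h; a lower number here means a stronger inhibitor, a higher number a weaker inhibitor:

compound 1, `O=C1c2c[n+]([O-])c3ccccc3c2C(=O)c2c1c1ccccc1n2CCCCN1CCCCC1`, gives 150 nM
compound 2, `CC1(C)OC[C@@H](Cn2cc(Cn3c4c(c5ccccc53)C(=O)c3c[n+]([O-])c5ccccc5c3C4=O)nn2)O1`, gives 4700 nM
compound 3, `O=C1c2c[n+]([O-])c3ccccc3c2C(=O)c2c1c1ccccc1n2Cc1cn([C@@H]2O[C@H](CO)[C@@H](O)[C@H](O)[C@H]2O)nn1`, gives 560 nM

Compound 1 stands lowest of the three numbers, with compound 3 nearest and compound 2 furthest. All three share one core and differ only in the group attached to its aromatic nitrogen. Among the measured compounds shown here, the single step between measured compounds, an 8.4-fold lower number from compound 2 to compound 3 (0.92 log units; beyond the scatter), concerns a sugar-like group replacing a protected diol on that nitrogen and so touches a different kind of change than the one now in question.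

Compound 4, `O=C1c2c[n+]([O-])c3ccccc3c2C(=O)c2c1c1ccccc1n2CCCCn1ccnc1`, keeps the four-carbon chain of compound 1 and changes only its end: 1H-imidazol-1-yl in place of piperidin-1-yl on a saturated chain carbon, four bonds along the chain from an aromatic nitrogen. For the measured compounds named here, no measured pair shows this exchange, so there is no direct guide to its size. The chain-bearing compound 1 is the lowest number seen, and the other measured variations on this nitrogen all read higher, so some rise is more likely than a fall. A modest weakening is expected, a 2.7-fold higher number from compound 1 to compound 4 (0.43 log units; beyond the scatter). For compound 4 the expected value in this assay is 400 nM, within a range from 100 nM to 2000 nM.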

Compound 4, half-maximal inhibitory concentration: 170 nM
Compound 4: middle estimate off by 2.4-fold (0.37 log units), on the high side; the range from low to high includes it.
By their numbers in this assay, from the lowest: compounds 1 and 4 (each within the scatter of the next); then compound 3; then compound 2.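

In this assay the step from piperidin-1-yl to 1H-imidazol-1-yl on a saturated chain carbon, four bonds along the chain from an aromatic nitrogen, is a 1.1-fold higher number from compound 1 to compound 4 (0.05 log units; within the scatter) and so cannot be told from no change. Among the compounds shown here, a six-membered non-aromatic ring and a five-membered aromatic ring therefore read alike at this place, whereas the earlier compounds showed only that very different groups on the aromatic nitrogen give different numbers. Nothing measured here accounts for why these two chain ends read alike.

Going by these compounds, what an open-chain amine such as dimethylamine or a carboxylic acid would give at the chain end remains open. Also open, on these data alone, is how a shorter or longer chain carrying either ring would read, so the part played by chain length cannot be judged.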